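Swapping acetyl for hydrogen on a weak compound

A few compounds are considered here, and "the series" means these few. Any claim that something is new, unique, unknown or untested is made for them only; others in the source may bear on it.

Compound 1 `COc1ccc(C2=C(c3cc(OC)c(OC)c(OC)c3)C(=O)C(OC(C)=O)C2)cc1OC(C)C` is the weakest of three related compounds measured in an ADME assay on HEp-2 cells (Homo sapiens) for cytotoxicity, read by MTT assay, with a stated time of 72 h; a lower number here means a stronger inhibitor, a higher number a weaker inhibitor. In this test, compound 1 gives > 100 ug/mL, which is a limit and not a number. Compound 2 `COc1ccc(C2=C(c3cc(OC)c(OC)c(OC)c3)C(=O)C(OC(C)=O)C2)cc1F` gives < 1 ug/mL, also a limit. Compound 3 `COc1ccc(C2=C(c3cc(OC)c(OC)c(OC)c3)C(=O)C(OC(C)=O)C2)cc1Cl` gives < 1 ug/mL, again a limit.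

Compound 4 `COc1ccc(C2=C(c3cc(OC)c(OC)c(OC)c3)C(=O)C(O)C2)cc1OC(C)C` differs from compound 1 at another place: hydrogen in place of acetyl on an oxygen on a saturated carbon. In words, this is hydrogen in place of acetyl on an oxygen on a saturated carbon, so acetoxy becomes hydroxy. Among the compounds with values here, no measured step tests this change directly. The two readable steps both replace isopropoxy, a group that compound 4 keeps: fluoro gives an at least 100-fold lower number from compound 1 to compound 2 (2.00 log units; beyond the scatter), and chloro gives an at least 100-fold lower number from compound 1 to compound 3 (2.00 log units; beyond the scatter). Both are large, but neither offers a size for the acetyl change, so the weak standing of compound 1 is the best guide. In this assay, the expected change is a number no higher from compound 1 to compound 4 (the limit leaves the size open), with no step beyond the scatter anticipated. The estimate for compound 4 is 100 ug/mL, with an expected range from 10 ug/mL to 300 ug/mL.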

Compound 4, half-maximal inhibitory concentration: > 100 ug/mL
Compound 4 was reported as a limit; the forecaster's own chance of this, stated with the estimate: 55%; the middle value sits exactly at the limit.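

Compound 1 and compound 4 are both reported only as limits, and the step between them cannot be read. The compounds shown leave open what acetoxy to hydroxy does to the number, both here and on stronger compounds such as compound 2 or compound 3.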